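Removing the methylpiperazine arm from compound 3

A few compounds are considered here, and "the series" means these few. Any claim that something is new, unique, unknown or untested is made for them only; others in the source may bear on it.

compound 1 `CN1CCN(Cc2ccc(NC(=O)Nc3ccc4ncnc(Nc5ccc(F)c(F)c5)c4c3)cc2)CC1`: > 10000 nM (a limit of the assay)
compound 2 `COc1ccc(Nc2ncnc3ccc(NC(=O)Nc4ccc(CN5CCN(C)CC5)cc4)cc23)cc1Cl`: 3570 nM
compound 3 `CN1CCN(Cc2ccc(NC(=O)Nc3ccc4ncnc(Nc5cccc(C(F)(F)F)c5)c4c3)cc2)CC1`: 1650 nM

In a functional assay on A549 cells (Homo sapiens) for antiproliferative activity, read by MTT assay, with a stated time of 72 h (a lower number here means a stronger inhibitor, a higher number a weaker inhibitor), compound 3 gives 1650 nM, the lowest number of the three, and its nearest neighbour is set apart by a 2.2-fold lower number from compound 2 to compound 3 (0.34 log units; beyond the scatter). Compound 4 `O=C(Nc1ccccc1)Nc1ccc2ncnc(Nc3cccc(C(F)(F)F)c3)c2c1` differs from it thus: hydrogen in place of (4-methylpiperazin-1-yl)methyl on an aromatic carbon. The measured steps, an at least 2.8-fold lower number from compound 1 to compound 2 (0.44 log units; beyond the scatter) and an at least 6.0-fold lower number from compound 1 to compound 3 (0.78 log units; beyond the scatter), rest on the limit of compound 1. Like the step between compound 2 and compound 3, they change only the group on the other nitrogen, so none measures this change directly. A modest move towards a higher number is therefore expected, with the direction uncertain: a 2.1-fold higher number from compound 3 to compound 4 (0.33 log units; beyond the scatter). For compound 4 the estimated value is 3500 nM, within a range of 700 nM to 15000 nM.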

Compound 4, half-maximal inhibitory concentration: > 10000 nM
Compound 4 was reported as a limit; the forecaster's own chance of this, stated with the estimate: 30%; middle value at least 2.8-fold (0.45 log units) away from the limit.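

Within the data shown here, with hydrogen in place of (4-methylpiperazin-1-yl)methyl on the aromatic carbon, this assay gives an at least 6.0-fold higher number from compound 3 to compound 4 (0.78 log units; beyond the scatter), the first direct reading of this change. The earlier steps shown here altered only the group on the other nitrogen, whereas this one shows that, with 3-(trifluoromethyl)phenyl held fixed, losing the arm moves the number upward beyond the scatter. The value of compound 4 is a limit of the assay, so the true size of this step cannot be read: the limit of > 10000 nM in this assay, at which 2 of the 4 values shown sit.

Going by these compounds, whether a dimethylaminomethyl group, a morpholinylmethyl group or a carboxylic acid in the same place would keep the number of compound 3 remains open. So does whether removing the arm has the same effect with 3-chloro-4-methoxyphenyl on the other nitrogen.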